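A few compounds are considered here, and "the series" means these few. Any claim that something is new, unique, unknown or untested is made for them only; others in the source may bear on it.

Working notes on the series, as read in a functional assay on HCT-116 cells (Homo sapiens) for antiproliferative activity; on this read-out lower numbers stand for stronger inhibition and higher numbers for weaker inhibition. Compound 1 `Cc1c2c(n3c1CCNC[C@@H](C)[C@H](C)Nc1cc-3ccc1C(N)=O)CC(C)(C)CC2=O`, with hydrogen on the amine nitrogen in a ring, gives 24 nM. Compound 2 `CC[C@H](N)C(=O)N1CCc2c(C)c3c(n2-c2ccc(C(N)=O)c(c2)N[C@@H](C)[C@H](C)C1)CC(C)(C)CC3=O` gives 33 nM, and compound 3 `Cc1c2c(n3c1CCN(C(=O)[C@@H](N)C(C)C)C[C@@H](C)[C@H](C)Nc1cc-3ccc1C(N)=O)CC(C)(C)CC2=O` gives 30 nM. Compound 3 lies within the scatter of both others, so it holds no distinct rank among the three.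

The next analogue is compound 4 `Cc1c2c(n3c1CCN(C(=O)C1(N)CC1)C[C@@H](C)[C@H](C)Nc1cc-3ccc1C(N)=O)CC(C)(C)CC2=O`, with the change 1-aminocyclopropyl in place of 1-amino-2-methylpropyl on a carbonyl carbon. Among the compounds with values here, three measured steps bear on it. Placing (1-aminopropyl)carbonyl on that nitrogen gives a 1.4-fold higher number from compound 1 to compound 2 (0.14 log units; within the scatter), and placing (1-amino-2-methylpropyl)carbonyl there gives a 1.3-fold higher number from compound 1 to compound 3 (0.10 log units; within the scatter). The added methyl on the chain gives a 1.1-fold lower number from compound 2 to compound 3 (0.04 log units; within the scatter). Within the data shown here, no measured compound carries the 1-aminocyclopropyl group, so the evidence is indirect. All three steps are small, so no step beyond the scatter is expected in this assay, and the expected step is no change at the digits printed from compound 3 to compound 4 (within the scatter). Compound 4 is estimated at 30 nM, with an expected range of 12 nM to 75 nM.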

Compound 4, half-maximal inhibitory concentration: 81 nM
Estimate against measurement, compound 4: 2.7-fold (0.43 log units) below; measured number outside the range, above it.
By their numbers in this assay, from the lowest: compounds 1, 3 and 2 (each within the scatter of the next); then compound 4.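

In this assay, the group on the carbonyl carbon matters at this amide-type nitrogen in a ring: 1-aminocyclopropyl in place of 1-amino-2-methylpropyl gives a 2.7-fold higher number from compound 3 to compound 4 (0.43 log units; beyond the scatter) and in place of 1-aminopropyl gives a 2.5-fold higher number from compound 2 to compound 4 (0.39 log units; beyond the scatter) while the two open-chain groups stay within the scatter of each other. Against hydrogen on that nitrogen, (1-aminocyclopropyl)carbonyl gives a 3.4-fold higher number from compound 1 to compound 4 (0.53 log units; beyond the scatter) and is the only one of the three groups on that nitrogen with a step beyond the scatter. No measurement at hand accounts for this shift.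

The change brings in a three-membered ring and also removes a defined stereocentre, and the compounds shown do not separate these two differences. From the compounds shown here alone, open-chain 1-amino-1-methylethyl, which has no stereocentre, and 1-aminocyclobutyl, which has a larger carbon ring, remain open on this carbonyl carbon.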